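From a Diethylamide to a Methoxyanilide

This account rests on a few compounds, and the source may have more. Where it says the series, first, only, none or still open, it means among the compounds named here.

Compound 1, `CCN(CC)C(=O)CN(c1cc(Cl)ccc1OC)S(=O)(=O)c1ccccc1`: in a functional assay on SH-SY5Y cells (Homo sapiens), read by MTT assay, with a stated time of 24 h (a higher number here means that more compound is needed for the effect, a lower number that less compound is needed), compound 1 gives > 20000 nM, which is a limit of the assay rather than a number.
Compound 2, `COc1ccc(Cl)cc1N(CC(=O)N(C1CCCCC1)C1CCCCC1)S(=O)(=O)c1ccccc1`: in this assay compound 2 gives 14300 nM.

The two measured compounds share the core of compound 1 and differ only at the amide end. Compound 1 stands at the limit of > 20000 nM in this assay, at which 1 of the 2 values shown sits, so its position is known only as a ceiling, not as a point. Among the compounds with values here, compound 2 is the only one of the pair that gives a number, and the two do not form a step that can be sized.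

Compound 3, `COc1ccccc1NC(=O)CN(c1cc(Cl)ccc1OC)S(=O)(=O)c1ccccc1`, comes from compound 1 by (2-methoxyphenyl)amino in place of diethylamino on a carbonyl carbon. Within the data shown here, no measured pair shows what such a change does, so the expectation rests on the two values above alone. The step from compound 1 to compound 3 is expected to be modest, an at least 1.3-fold lower number from compound 1 to compound 3 (0.12 log units; that floor lies within the scatter), without a clear direction beyond the scatter. Compound 3 is expected to give about 15000 nM, between 5000 nM and 40000 nM.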

Compound 3, half-maximal effective concentration: 15500 nM
The estimate for compound 3 lay 1.0-fold (0.01 log units) below the measured number; the range from low to high includes it.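

In this assay compound 3, with the new group on the same carbonyl carbon, gives 15500 nM. The change can be sized only as a floor, an at least 1.2-fold lower number from compound 1 to compound 3 (0.11 log units; that floor lies within the scatter), so the step may be small or may be larger. Compound 2 gives 14300 nM, close to the printed value of compound 3, so these two quite different amide ends, only one of which carries an amide hydrogen, read much alike here.

From the compounds shown here alone, what a plain phenylamino group or a piperidine ring would give at this carbonyl carbon stays open, as does the part played by the methoxy group on the new ring. The true size of the step also stays open, as compound 1 is still a limit and not a number: the limit of > 20000 nM in this assay, at which 1 of the 3 values shown sits.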